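A few compounds are considered here, and "the series" means these few. Any claim that something is new, unique, unknown or untested is made for them only; others in the source may bear on it.

Compound 1 `COC(=O)/C(=C/c1ccccc1)CN1C(=O)[C@@H](OC)[C@H]1c1ccc(Cl)cc1Cl` no result reported
Compound 2 `COC(=O)/C(=C/c1ccccc1)CN1C(=O)[C@@H](OC)[C@H]1c1ccc(OC)cc1` measured at 11600 nM

Going by the values given here, in a functional assay on MCF7 cells (Homo sapiens) for antiproliferative activity, read by MTT assay, with a stated time of 48 h (on this read-out higher numbers stand for weaker inhibition and lower numbers for stronger inhibition), compound 2 gives 11600 nM as the only number so far, so it cannot yet be ranked against another compound. Compound 3 `COC(=O)/C(=C/c1ccccc1)CN1C(=O)[C@@H](OC)[C@H]1c1ccccc1` is still to be measured. It differs from compound 2 by hydrogen in place of methoxy on an aromatic carbon with hydrogen in place of methoxy on an aromatic carbon. Among the compounds with values here, no measured step bears on this change, so only a small move toward weaker inhibition in this assay is expected, possibly none beyond the scatter. The expected change is a 1.3-fold higher number from compound 2 to compound 3 (0.11 log units; within the scatter) on this estimate. For compound 3 the estimated value is 15000 nM with an expected range from 5000 nM to 45000 nM for now.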

Compound 3, half-maximal inhibitory concentration: 12900 nM
Estimate against measurement, compound 3: 1.2-fold (0.07 log units) above, within the range that was stated.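

Going from 4-methoxyphenyl to phenyl gives a 1.1-fold higher number from compound 2 to compound 3 (0.05 log units; within the scatter) in this assay. On this read-out, methoxy and hydrogen on the aromatic carbon para to a large group cannot be told apart, so the methoxy is not needed to hold the micromolar-range number of compound 2. Nothing available explains this result.

One pair at one position cannot show whether this tolerance extends to other groups. An amine, a carboxylic acid or a longer chain at the same carbon remains an open case.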